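The source may report more compounds than this note shows. Statements on the series, on what has been measured and on what is new or still open speak of the compounds shown alone.

Compound 1 `c1ccc(C2CNCCNCCNCCN2)cc1` carries a phenyl on a saturated carbon of its core. In an ADME assay on HEK293 cells (Homo sapiens) for cytotoxicity (on this read-out lower numbers stand for an effect already at smaller amounts and higher numbers for an effect only at larger amounts of compound), compound 1 gives only a limit of the assay, > 200000 nM. Compound 2 `O=[N+]([O-])c1ccc(C2CNCCNCCNCCN2)cc1`, which has nitro in place of hydrogen on an aromatic carbon, likewise gives only a limit in this assay, > 200000 nM. The step that the two limits leave unreadable from compound 1 to compound 2 therefore has no readable size, because of the limit of > 200000 nM in this assay, at which 2 of the 2 values shown sit. Compound 3 `CC(C)(C)C1CNCCNCCNCCN1` has not yet been measured in this assay; it differs from compound 1 by tert-butyl in place of phenyl on a saturated ring carbon. Within the data shown here, the only measured step, from compound 1 to compound 2, concerns a different change and cannot be sized, so it supports no expectation of a shift in either direction beyond the scatter. Compound 3 is expected to give a value of 200000 nM in this assay, within a range from 100000 nM to 400000 nM. The expected step of a number no higher from compound 1 to compound 3 (the limit leaves the size open) is thus essentially none.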

Compound 3, half-maximal effective concentration: > 200000 nM
Compound 3: only a limit was reported (the forecaster's own chance of this, stated with the estimate: 85%); the middle value sits exactly at the limit.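

Among these compounds, compound 3, like compound 1, gives only a limit in this assay, so no step between compound 1 and compound 3 can be read, because all values sit at that limit: the limit of > 200000 nM in this assay, at which 3 of the 3 values shown sit. The compounds shown leave open at what concentration any of them would produce an effect on these cells.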